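The source may hold more compounds than are shown below. What is called first, only, known or untested is meant among the compounds shown, and "the series" means these compounds.

Measured so far in a functional assay on MT4 cells (Homo sapiens) for cytotoxicity; a lower number here means that less compound is tolerated, a higher number that more compound is tolerated:
- compound 1, `Cc1nc(S)n(Nc2cccc(Cl)c2)c1-c1ccc(Br)cc1`: in this assay compound 1 gives 33200 nM
- compound 2, `Cc1nc(S)n(Nc2cccc(Cl)c2)c1-c1cccc(Cl)c1`: in this assay compound 2 gives 31000 nM

Compound 2 carries the smaller of the two numbers, but the gap to compound 1 is within the scatter, so the two values are not distinguishable; a 1.1-fold lower number from compound 1 to compound 2 (0.03 log units; within the scatter).

Compound 3, `Cc1nc(S)n(Nc2cccc(Cl)c2)c1-c1ccc(Cl)cc1`, has not yet been measured. It differs from compound 2 in one place: 4-chlorophenyl in place of 3-chlorophenyl on an aromatic carbon. Among the measured compounds shown here, the only measured step that bears on this is the one from compound 1 to compound 2, where one halogenated phenyl group was traded for another on the same aromatic carbon and the number did not move beyond the scatter. Compound 3 keeps the same atoms as compound 2, joined differently, and so falls into the same kind of exchange. No step beyond the scatter is therefore expected for compound 3 in this assay; the estimate is a 1.0-fold higher number from compound 2 to compound 3 (0.01 log units; within the scatter).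

For compound 3 the expected value in this assay is 32000 nM, with a range from 16000 nM to 64000 nM.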

Compound 3, half-maximal cytotoxic concentration: 40800 nM
Estimate against measurement, compound 3: 1.3-fold (0.11 log units) below, within the range that was stated.
By their numbers in this assay, from the lowest: compounds 2, 1 and 3 (each within the scatter of the next).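

Read in this assay, this is the first exchange at this aromatic carbon that keeps the halogen the same and alters only where it sits on the phenyl group: 4-chlorophenyl in place of 3-chlorophenyl gives a 1.3-fold higher number from compound 2 to compound 3 (0.12 log units; within the scatter), so the two chlorophenyl isomers cannot be told apart here. The exchange of chloro for bromo, with the halogen kept on the 4-substituted phenyl group, gives a 1.2-fold higher number from compound 1 to compound 3 (0.09 log units; within the scatter), and it separates the halogen exchange from the change of placement, both of which were combined in the step between compound 1 and compound 2; neither exchange taken alone leaves the scatter. Nothing measured alongside these numbers offers an explanation for them.

All three compounds carry a halogenated phenyl group at this carbon, so the data say nothing about how the number responds when that group gives way to a pyridine, a phenyl group bearing a carboxylic acid or an amine, or a longer alkyl chain. The sulfanyl group, the methyl group and the group of 8 heavy atoms on the shared core are also the same throughout, so replacing the methyl with an ethyl group, for example, remains an open question.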